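Urea-pyrazole series: removing the methyl from compound 2

The source may report more compounds than this note shows. Statements on the series, on what has been measured and on what is new or still open speak of the compounds shown alone.

Measured compounds in a functional assay on PC-3 cells (Homo sapiens) for inhibition, read by sulforhodamine B assay, with a stated time of 48 h; on this read-out lower numbers stand for stronger inhibition of growth and higher numbers for weaker inhibition of growth:
- compound 1 `O=C(Nc1cccc(-n2cc(-c3ccncc3)c(-c3ccc(Cl)c(O)c3)n2)c1)Nc1cccc(C(F)(F)F)c1` gives 948 nM
- compound 2 `COc1cc(-c2nn(-c3cccc(NC(=O)Nc4cc(C(F)(F)F)cc(C(F)(F)F)c4)c3)cc2-c2ccncc2)ccc1Cl` gives 250 nM
- compound 3 `COc1cc(-c2nn(-c3cccc(NC(=O)Nc4cccc(C(F)(F)F)c4)c3)cc2-c2ccncc2)ccc1Cl` gives 372 nM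

Compound 2 has the lowest number of the three in this assay; compound 3 sits within the scatter of it, and compound 1 lies beyond the scatter, higher.

Compound 4 `O=C(Nc1cccc(-n2cc(-c3ccncc3)c(-c3ccc(Cl)c(O)c3)n2)c1)Nc1cc(C(F)(F)F)cc(C(F)(F)F)c1` is not yet measured. It differs from compound 2 in one place: hydrogen in place of methyl on an oxygen on an aromatic ring. The same change, run the other way, is already on record: a 2.5-fold lower number from compound 1 to compound 3 (0.41 log units; beyond the scatter). That step is the only one that bears directly on this change; the other recorded step, a 1.5-fold higher number from compound 2 to compound 3 (0.17 log units; within the scatter), concerns the trifluoromethyl end of the urea and lies within the scatter, so it does not alter the picture.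

Reversing the methyl-for-hydrogen step, a higher number in this assay is expected for compound 4, and the expected step is a 2.5-fold higher number from compound 2 to compound 4 (0.40 log units; beyond the scatter). Compound 4 is therefore estimated at 630 nM, with a range from 300 nM to 1300 nM.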

Compound 4, concentration for 50% growth inhibition: 319 nM
For compound 4 the middle estimate is 2.0-fold (0.30 log units) above the measured one, within the range that was stated.
By their numbers in this assay, from the lowest: compounds 2, 4 and 3 (each within the scatter of the next); then compound 1.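

In this assay, hydroxy in place of methoxy on the core carrying two trifluoromethyl groups gives a 1.3-fold higher number from compound 2 to compound 4 (0.11 log units; within the scatter), so the step beyond the scatter seen for this change on the other core does not recur here. The two readings of the change still cannot be told apart: the same change on two cores in this assay, a 2.5-fold lower number (0.41 log units; beyond the scatter) from compound 1 to compound 3 and a 1.3-fold lower number (0.11 log units; within the scatter) from compound 4 to compound 2, 2.0-fold (0.30 log units) apart, within the scatter of two such steps. Adding the second trifluoromethyl to the hydroxy core gives a 3.0-fold lower number from compound 1 to compound 4 (0.47 log units; beyond the scatter), a step beyond the scatter, whereas the same change on the methoxy core stays within it, although these two steps cannot be told apart either: the same change on two cores in this assay, a 1.5-fold higher number (0.17 log units; within the scatter) from compound 2 to compound 3 and a 3.0-fold higher number (0.47 log units; beyond the scatter) from compound 4 to compound 1, 2.0-fold (0.30 log units) apart, within the scatter of two such steps.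

Going by these compounds, what an amine or a longer chain such as ethoxy would give on this aromatic ring remains open. With only this assay shown, it is also open whether these steps hold on other cells.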